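The source may report more compounds than this note shows. Statements on the series, on what has been measured and on what is new or still open speak of the compounds shown alone.

In an assay on CHO cells for displacement of a labelled ligand from Substance-P receptor (Homo sapiens) (on this read-out higher numbers stand for weaker inhibition and lower numbers for stronger inhibition), compound 2 `C[C@@H](O[C@H]1CN2C(=O)C=C(c3ccncc3)CC2[C@@H]1c1ccc(F)cc1)c1cc(C(F)(F)F)cc(C(F)(F)F)c1` gives 0.14 nM, the lowest of the two numbers measured here; its nearest neighbour, compound 1 `C[C@@H](O[C@H]1CN2C(=O)C=C(c3ccc(C#N)cc3)CC2[C@@H]1c1ccc(F)cc1)c1cc(C(F)(F)F)cc(C(F)(F)F)c1`, gives 1.8 nM, and the step of a 13-fold lower number from compound 1 to compound 2 (1.11 log units; beyond the scatter) is a large one. Compound 3 `COc1cc(C2=CC(=O)N3C[C@H](O[C@H](C)c4cc(C(F)(F)F)cc(C(F)(F)F)c4)[C@@H](c4ccc(F)cc4)C3C2)ccn1` is reached from compound 2 by a small change: methoxy in place of hydrogen on an aromatic carbon. Within the data shown here, the only measured step exchanges one whole aromatic group for another and so tells nothing about adding a methoxy group; no step bears on this change. The step expected is therefore a 1.4-fold higher number from compound 2 to compound 3 (0.15 log units; within the scatter), nothing clearly beyond the scatter. Compound 3 is estimated at 0.2 nM, within 0.06 nM to 0.7 nM.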

Compound 3, half-maximal inhibitory concentration: 1.1 nM
For compound 3 the middle estimate is 5.5-fold (0.74 log units) below the measured one; the measured number lies above the stated range.
By their numbers in this assay, from the lowest: compound 2; then compounds 3 and 1 (each within the scatter of the next).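

In this assay, methoxy next to the ring nitrogen of the pyridin-4-yl group is no neutral addition, giving a 7.9-fold higher number from compound 2 to compound 3 (0.90 log units; beyond the scatter) at this position. Most of the gain of the pyridin-4-yl group is thereby lost, and a 1.6-fold lower number from compound 1 to compound 3 (0.21 log units; within the scatter) leaves 2-methoxypyridin-4-yl not clearly different from 4-cyanophenyl. Nothing measured here explains this loss. Still open, as far as these compounds go, is whether a methyl group, an amine or a chlorine atom on the same carbon would cost as much, and whether a smaller ether-free group would be tolerated there.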